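The source may hold more compounds than are shown below. What is called first, only, known or untested is meant among the compounds shown, and "the series" means these compounds.

Among the compounds with values here, in a functional assay on NPC-TW01 cells (Homo sapiens) for inhibition, read by MTT assay, with a stated time of 72 h (on this read-out lower numbers stand for stronger inhibition of growth and higher numbers for weaker inhibition of growth), compound 1 (`CN(C)/C=N/c1c(C=O)c(-c2ccccc2)nn1-c1ccccc1`) gives 9300 nM, the only exact number so far. Compound 2 (`CN(C)/C=N/c1cc(-c2ccccc2)nn1-c1ccccc1`) carries hydrogen in place of the formyl group, and its > 100000 nM is a limit of the assay, not a number. Compound 3 (`Nc1c(C=O)c(-c2ccccc2)nn1-c1ccccc1`) keeps the formyl group and changes a different place on compound 1: one nitrogen atom in place of a group of 5 heavy atoms (3 carbon, 2 nitrogen; no ring), on an aromatic carbon. In words, one nitrogen atom replaces a group of 5 heavy atoms, on an aromatic carbon next to the ring atom that bears a formyl group. Within the data shown here, no measured step touches this place. Among the measured compounds shown here, the nearest guide is the large step of an at least 10-fold higher number from compound 1 to compound 2 (1.03 log units; beyond the scatter), which shows only that a single change on the shared core can matter greatly. A smaller move towards weaker inhibition of growth is therefore expected, and the expected step is a 2.7-fold higher number from compound 1 to compound 3 (0.43 log units; beyond the scatter). For compound 3 the estimated value is 25000 nM, with an expected range of 6000 nM to 100000 nM.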

Compound 3, concentration for 50% growth inhibition: > 100000 nM
Compound 3: no number, only a limit (the forecaster's own chance of this, stated with the estimate: 20%); middle value at least 4.0-fold (0.60 log units) away from the limit.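

Within the data shown here, removing the group of 5 heavy atoms from this aromatic carbon and placing amino there gives an at least 10-fold higher number from compound 1 to compound 3 (1.03 log units; beyond the scatter) in this assay, so this position matters as well as the one carrying the formyl group. Keeping the formyl group is therefore not enough on its own: among the compounds shown, only compound 1, with both groups in place, gives an exact number, 9300 nM. The full size of this step cannot be read, since the value for compound 3 is a limit and not a number: the limit of > 100000 nM in this assay, at which 2 of the 3 values shown sit.

From the compounds shown here alone, it remains open whether a measurable value would return with a group of intermediate size at this position, such as methylamino or dimethylamino, or with an acetamide. Going by these compounds, it is also open whether a carboxylic acid or a nitrile could stand in place of the formyl group.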